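Swapping chloro for methoxy on a second core

A few compounds are considered here, and "the series" means these few. Any claim that something is new, unique, unknown or untested is made for them only; others in the source may bear on it.

Measured compounds:
- compound 1, `Cc1cc(C)c2c(O)cc(-c3ccc(Cl)cc3)nc2n1`: 3630 nM
- compound 2, `COc1ccc(-c2cc(O)c3c(C)cc(C)nc3n2)cc1`: 33100 nM
- compound 3, `Cc1cnc2nc(-c3ccc(Cl)cc3)cc(O)c2c1`: 562 nM

In a functional assay on MDA-N cells (Homo sapiens) (a higher number here means a weaker inhibitor of growth, a lower number a stronger inhibitor of growth), compound 3 gives 562 nM, the lowest of the three numbers; compound 1 gives 3630 nM and compound 2 gives 33100 nM. The difference between the cores of compound 1 and compound 3 is not broken down here. Within the core of compound 1, the change methoxy in place of chloro on an aromatic carbon made the step of a 9.1-fold higher number from compound 1 to compound 2 (0.96 log units; beyond the scatter). Compound 4, `COc1ccc(-c2cc(O)c3cc(C)cnc3n2)cc1`, applies the same change to compound 3: methoxy in place of chloro on an aromatic carbon, at a place described in the same words as before. Within the data shown here, since only one example of this change is measured, the expectation rests on it alone: a step of an 8.9-fold higher number from compound 3 to compound 4 (0.95 log units; beyond the scatter) is expected for compound 4 because compound 2 shows a 9.1-fold higher number from compound 1 to compound 2 (0.96 log units; beyond the scatter). Compound 4 is therefore estimated at 5000 nM in this assay, roughly between 1500 nM and 20000 nM.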

Compound 4, concentration for 50% growth inhibition: 1700 nM
For compound 4 the middle estimate is 2.9-fold (0.47 log units) above the measured one; the measured number falls inside the stated range.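

In this assay, methoxy in place of chloro again gives a higher number on the second core, a weaker inhibitor of growth, with a step of a 3.0-fold higher number from compound 3 to compound 4 (0.48 log units; beyond the scatter). The direction of the change carries over, but its size does not: the same change on two cores in this assay, a 9.1-fold higher number (0.96 log units; beyond the scatter) from compound 1 to compound 2 and a 3.0-fold higher number (0.48 log units; beyond the scatter) from compound 3 to compound 4, 3.0-fold (0.48 log units) apart, beyond the scatter of two such steps. Two cores show only that the size can differ from one core to another, not which difference between the cores is responsible or how large the step would be on a further core.

The compounds shown leave open how an amine or a carboxylic acid on this aromatic carbon would compare with chloro and methoxy. They also leave open whether such groups would shift the number equally on both cores.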